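The compounds below may be only part of what the source reports. "The series", "measured", "known", "first", "only" and "open" are said of these compounds alone.

Going by the values given here, the three compounds measured so far share one core and differ only in what sits on the outer phenyl ring. Compound 1 `O=C1NCCN1c1ccc(S(=O)(=O)Nc2ccccc2)cc1` carries nothing there, and in a functional assay on M21 cells (Homo sapiens) for antiproliferative activity, read by sulforhodamine B assay, with a stated time of 48 h (a higher number here means a weaker inhibitor, a lower number a stronger inhibitor), compound 1 gives 200 nM. Compound 2 `O=C1NCCN1c1ccc(S(=O)(=O)Nc2ccc(Cl)cc2)cc1` gives 90 nM, and compound 3 `COc1ccc(NS(=O)(=O)c2ccc(N3CCNC3=O)cc2)cc1OC` gives 340 nM. Of the three numbers, that of compound 3 is the largest, but the gap to compound 1 lies within the scatter, so the two cannot be ranked; the gap to compound 2 lies beyond it.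

Compound 4 `COc1cccc(NS(=O)(=O)c2ccc(N3CCNC3=O)cc2)c1` differs from compound 3 in one place: hydrogen in place of methoxy on an aromatic carbon. Among the compounds with values here, only one measured step alters a group on that ring, a 2.2-fold lower number from compound 1 to compound 2 (0.35 log units; beyond the scatter), and it concerns a different group, so it does not speak directly to the removal of a methoxy. Between compound 1 and compound 3 no single step is given, but their two values lie within the scatter, which shows that carrying two methoxy groups or none makes little difference here. Taking one of them away is therefore expected to leave compound 4 near compound 3, with a 1.3-fold lower number from compound 3 to compound 4 (0.12 log units; within the scatter) expected to stay within the scatter. Compound 4 is estimated at 260 nM, with a range from 120 nM to 550 nM.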

Compound 4, half-maximal inhibitory concentration: 65 nM
The estimate for compound 4 lay 4.0-fold (0.60 log units) above the measured number; measured number below the stated range.
By their numbers in this assay, from the lowest: compounds 4 and 2 (each within the scatter of the next); then compounds 1 and 3 (each within the scatter of the next).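

In this assay, taking away the methoxy that sits ortho to a methoxy group and para to a large group gives a 5.2-fold lower number from compound 3 to compound 4 (0.72 log units; beyond the scatter), so this single position matters, even though compound 1 and compound 3 could not be ranked. Placing one methoxy on the bare outer ring gives a 3.1-fold lower number from compound 1 to compound 4 (0.49 log units; beyond the scatter), while the two methoxy groups of compound 3 leave it unranked against compound 1, so among these compounds the changes from methoxy groups on this ring do not simply add up. The 3-methoxyphenyl group of compound 4 also proves a match for the 4-chlorophenyl group, with a 1.4-fold lower number from compound 2 to compound 4 (0.14 log units; within the scatter), so compound 2 and compound 4 cannot be ranked.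

Going by these compounds alone, open is whether the low number of compound 4 depends on the methoxy itself, which a hydroxyl, an amine or a longer chain such as ethoxy on that same carbon could test, and whether a methoxy alone on the carbon para to a large group would act like the one in compound 4. Nothing in the data at hand explains why the second methoxy of compound 3 goes with a higher number.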